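The compounds below may be only part of what the source reports. "The series", "measured", "known", "first", "only" and "open" are said of these compounds alone.

Measured compounds and their numbers:
- compound 1, `N#CC1=C(N)N(c2ccc(S(N)(=O)=O)cc2)C2=C(CCCC2)C1c1ccccc1O`: 50% in a functional assay on Ehrlich cells (Mus musculus) for cytotoxicity, read by trypan blue exclusion, with a stated time of 2 h, tested at 50 ug/mL; on this read-out higher numbers stand for a stronger effect at the one concentration tested and lower numbers for a weaker effect
- compound 2, `COc1ccccc1C1C(C#N)=C(N)N(c2ccc(S(N)(=O)=O)cc2)C2=C1CCCC2`: 50%
- compound 3, `COc1ccc(C2C(C#N)=C(N)N(c3ccc(S(N)(=O)=O)cc3)C3=C2CCCC3)cc1`: 100%

Compound 3 stands highest of these three numbers. Its nearest neighbour is compound 1, a number 50 percentage points higher from compound 1 to compound 3 (beyond the scatter), and its furthest is compound 2, a number 50 percentage points higher from compound 2 to compound 3 (beyond the scatter).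

Compound 4, `N#CC1=C(N)N(c2ccc(S(N)(=O)=O)cc2)C2=C(CCCC2)C1c1ccc(Cl)c(Cl)c1`, has not yet been measured in this assay. It differs from compound 3 in one place: 3,4-dichlorophenyl in place of 4-methoxyphenyl on a saturated ring carbon.

For the measured compounds named here, two measured steps concern the same saturated ring carbon and both were large: a number 50 percentage points higher from compound 1 to compound 3 (beyond the scatter) and a number 50 percentage points higher from compound 2 to compound 3 (beyond the scatter). Going by the values given here, neither of them brings in a ring bearing chlorine, so they show only that a change of the aryl group at this place can move the read-out strongly. The other step, no change at the digits printed from compound 1 to compound 2 (within the scatter), lay within the scatter. The number of compound 3 already sits at the top of the scale, so no rise can appear; a moderate fall is expected, a number 25 percentage points lower from compound 3 to compound 4 (beyond the scatter). Compound 4 is therefore estimated at 75%, with a range from 40% to 100%.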

Compound 4, a percentage reported as activity, at one concentration (the size of the read-out at that concentration, not a potency): 50%
Estimate against measurement, compound 4: 25 percentage points above; the measured number falls inside the stated range.
By their numbers in this assay, from the lowest: compounds 1, 2 and 4 (each within the scatter of the next); then compound 3.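

In this assay the first aryl group bearing chlorine at this saturated ring carbon gives a number 50 percentage points lower from compound 3 to compound 4 (beyond the scatter) and so does not keep the top read-out of the 4-methoxyphenyl group. The 3,4-dichlorophenyl group also shows no change at the digits printed from compound 2 to compound 4 (within the scatter) and no change at the digits printed from compound 1 to compound 4 (within the scatter), which leaves three differently substituted rings level and the 4-methoxyphenyl ring of compound 3 alone at the top among these four compounds. No measurement is available here that explains why these aryl groups differ.

The compounds shown leave open how a plain phenyl, a 4-chlorophenyl or a 4-aminophenyl group would read at this carbon, which would help show how far the high read-out is tied to the 4-methoxyphenyl group. Also open, from the compounds shown here alone, is whether a carboxylic acid in place of the cyano group would change the picture.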